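Thioether side-chain variation on the shared core

The source may hold more compounds than are shown below. What is called first, only, known or untested is meant among the compounds shown, and "the series" means these compounds.

In a functional assay on SMMC-7721 cells (Homo sapiens) for antiproliferative activity, read by CCK-8 assay, with a stated time of 48 h (on this read-out higher numbers stand for weaker inhibition and lower numbers for stronger inhibition), compound 1 `CC(C)CSc1n[nH]c(-n2[se]c3ccccc3c2=O)n1` gives 35000 nM. Compound 2 `Cc1ccc(CSc2n[nH]c(-n3[se]c4ccccc4c3=O)n2)cc1` returns only a limit of the assay in this assay, > 50000 nM. The step of an at least 1.4-fold higher number from compound 1 to compound 2 (0.15 log units; that floor lies within the scatter) is bounded by that floor, since compound 2 sits at the limit of > 50000 nM in this assay, at which 1 of the 2 values shown sits. Compound 3 `O=c1c2ccccc2[se]n1-c1nc(SCc2ccc([N+](=O)[O-])cc2)n[nH]1` differs from compound 2 by nitro in place of methyl on an aromatic carbon. Among the measured compounds shown here, no measured step here exchanges nitro for methyl, so the sole bearing is the limit at which compound 2 stands, and no move beyond the scatter is expected in this assay. Compound 3 is thus expected at 50000 nM, ranging from 25000 nM to 100000 nM, a step of a number no higher from compound 2 to compound 3 (the limit leaves the size open).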

Compound 3, half-maximal inhibitory concentration: 8910 nM
Compound 3: the middle estimate sits 5.6-fold (0.75 log units) above what was measured; the whole stated range lies above it.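

In this assay, the aromatic ring on the thioether side chain responds to substitution: nitro in place of methyl on an aromatic carbon, para to a large group, gives an at least 5.6-fold lower number from compound 2 to compound 3 (0.74 log units; beyond the scatter). The only earlier step had a floor within the scatter, so this is the first change in the series shown to exceed it. Its true size stays open, as compound 2 gives only a limit of the assay: the limit of > 50000 nM in this assay, at which 1 of the 3 values shown sits.

With only methyl and nitro shown at this place, the trend across substituents remains undefined. An amine or a carboxylic acid on this aromatic carbon would help test it.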